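1,3-Thiazol-2-yl in place of thiophen-2-yl: series notes

The source may hold more compounds than are shown below. What is called first, only, known or untested is meant among the compounds shown, and "the series" means these compounds.

In a functional assay on DU-145 cells (Homo sapiens), read by sulforhodamine B assay, with a stated time of 5 days (a lower number here means a stronger inhibitor of growth, a higher number a weaker inhibitor of growth), compound 2 `OC[C@H]1O[C@@H](n2cc(F)c3c(-c4cccs4)ncnc32)[C@H](O)[C@@H]1O` gives 9 nM. Compound 1 `OC[C@H]1O[C@@H](n2cc(F)c3c(-c4ccco4)ncnc32)[C@H](O)[C@@H]1O` gives 5 nM, and the two values lie within the scatter of each other. Compound 3 `OC[C@H]1O[C@@H](n2cc(F)c3c(-c4nccs4)ncnc32)[C@H](O)[C@@H]1O` carries 1,3-thiazol-2-yl in place of thiophen-2-yl on an aromatic carbon of the shared core: 1,3-thiazol-2-yl in place of thiophen-2-yl on an aromatic carbon. For the measured compounds named here, the only measured step that bears on this exchange is thiophen-2-yl in place of furan-2-yl, a 1.8-fold higher number from compound 1 to compound 2 (0.26 log units; within the scatter), which lies within the scatter. Going by the values given here, no measured step introduces 1,3-thiazol-2-yl, so the evidence is thin and the range is kept wide, more so toward higher numbers in this assay. No step beyond the scatter is expected, and the estimated step is a 1.7-fold higher number from compound 2 to compound 3 (0.22 log units; within the scatter). For compound 3 the expected value is 15 nM, with an estimated range of 5 nM to 60 nM.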

Compound 3, concentration for 50% growth inhibition: 24 nM
For compound 3 the middle estimate is 1.6-fold (0.20 log units) below the measured one; the measured number falls inside the stated range.
By their numbers in this assay, from the lowest: compounds 1 and 2 (each within the scatter of the next); then compound 3.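

In this assay, the position proves sensitive to the identity of the five-membered aromatic ring: 1,3-thiazol-2-yl in place of thiophen-2-yl, which brings in a ring nitrogen, gives a 2.7-fold higher number from compound 2 to compound 3 (0.43 log units; beyond the scatter), a modest step beyond the scatter, unlike the exchange of furan-2-yl for thiophen-2-yl. Against furan-2-yl, the same group gives a 4.8-fold higher number from compound 1 to compound 3 (0.68 log units; beyond the scatter), so the position accepts all three rings, but 1,3-thiazol-2-yl stands apart from the other two by a modest margin. Nothing available accounts for this difference.

On these data alone, whether the ring nitrogen itself or its placement within the ring governs the step remains open, and 1,3-thiazol-5-yl would address that. Also open, as far as these compounds go, is whether this position needs an aromatic ring at all, which an amine or a methoxy group here would test.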